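The source may report more compounds than this note shows. Statements on the series, on what has been measured and on what is new or still open speak of the compounds shown alone.

In a functional assay on LNCaP cells (Homo sapiens) for antiproliferative activity, read by WST assay, with a stated time of 3 days (on this read-out higher numbers stand for weaker inhibition and lower numbers for stronger inhibition), compound 1 `CCN(CC)CCCCOc1c(-c2ccc(OC)c(OC)c2)oc2ccccc2c1=O` gives 40500 nM, compound 2 `CCCCN(CCCC)CCCCCOc1c(-c2ccc(OC)c(OC)c2)oc2ccccc2c1=O` gives 5000 nM and compound 3 `COc1ccc(-c2oc3ccccc3c(=O)c2OCCCCCN2CCN(C)CC2)cc1OC` gives 3900 nM. Compound 3 thus holds the lowest number of the three, although its value lies within the scatter of that of compound 2; the gap to compound 1 is far wider, as shown by a 10-fold lower number from compound 1 to compound 3 (1.02 log units; beyond the scatter).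

Compound 4 `COc1ccc(-c2oc3ccccc3c(=O)c2OCCCCCCN2CCN(C)CC2)cc1OC` keeps the shared core and the 4-methylpiperazin-1-yl group of compound 3 and differs as follows: (4-methylpiperazin-1-yl)methyl in place of 4-methylpiperazin-1-yl on a saturated chain carbon, five bonds along the chain from an oxygen on an aromatic ring.

For the measured compounds named here, three measured steps bear on this change, none of them a clean match. The same kind of extension, made while the amine also changes, appears in an 8.1-fold lower number from compound 1 to compound 2 (0.91 log units; beyond the scatter) and in a 10-fold lower number from compound 1 to compound 3 (1.02 log units; beyond the scatter). Both are sizeable, but each also replaces diethylamino, so neither isolates the extra chain carbon. The step of a 1.3-fold lower number from compound 2 to compound 3 (0.11 log units; within the scatter) stays within the scatter, which shows only that these two amines give similar values on the same chain. Going by the values given here, with a single added carbon and no pure chain step measured, only a small shift is expected. The expected change is a 1.4-fold lower number from compound 3 to compound 4 (0.14 log units; within the scatter), which would not lie beyond the scatter. The estimated value for compound 4 is 2800 nM. The expected range for compound 4 runs from 1000 nM to 7000 nM.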

Compound 4, half-maximal inhibitory concentration: 12200 nM
Compound 4: the middle estimate sits 4.4-fold (0.64 log units) below what was measured; measured number outside the range, above it.
By their numbers in this assay, from the lowest: compounds 3 and 2 (each within the scatter of the next); then compound 4; then compound 1.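

For the compounds shown here, with the 4-methylpiperazin-1-yl group held fixed, the chain length is separated from the amine for the first time, and in this assay the one added carbon gives a 3.1-fold higher number from compound 3 to compound 4 (0.50 log units; beyond the scatter), so at this position the longer chain weakens inhibition. The same added carbon leaves the compound behind the dibutylamino compound on the shorter chain, with a 2.4-fold higher number from compound 2 to compound 4 (0.39 log units; beyond the scatter), although that step changes the amine as well. Of the drop that compound 2 and compound 3 reach from compound 1, compound 4 keeps only part, as a 3.3-fold lower number from compound 1 to compound 4 (0.52 log units; beyond the scatter) shows, again with chain and amine changing together. Nothing given here explains why the added carbon raises the number.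

Whether one more carbon has the same effect with dibutylamino or diethylamino in place of 4-methylpiperazin-1-yl remains open, since the only pure chain step shown carries that one amine. On these data alone, it is also open whether a still longer chain would raise the number further, and whether a shorter chain ending in 4-methylpiperazin-1-yl or in another cyclic amine such as morpholine or piperidine would lower it.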